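Isopropyl on the Aryl Nitrogen: One Change, Two Cores

A few compounds are considered here, and "the series" means these few. Any claim that something is new, unique, unknown or untested is made for them only; others in the source may bear on it.

Compound 1 `CC(C)(C)c1ccc(O)c(NCCCN2CCN(C(c3ccccc3)c3ccc(Cl)cc3)CC2)c1` gives 0.068 ug/mL in a functional assay on the whole organism with Rattus norvegicus as the target; on this read-out lower numbers stand for stronger inhibition and higher numbers for weaker inhibition. Compound 2 `CC(C)N(CCCN1CCN(C(c2ccccc2)c2ccc(Cl)cc2)CC1)c1cc(C(C)(C)C)ccc1O` carries the change isopropyl in place of hydrogen on a nitrogen on an aromatic ring and gives 0.39 ug/mL; the step of a 5.7-fold higher number from compound 1 to compound 2 (0.76 log units; beyond the scatter) weakens inhibition. Compound 3 `Cc1ccc(O)c(NCCCN2CCN(C(c3ccc(Cl)cc3)c3ccc(Cl)cc3)CC2)c1` gives 0.48 ug/mL; the difference between its core and that of compound 1 is not broken down here. Compound 4 `Cc1ccc(O)c(N(CCCN2CCN(C(c3ccc(Cl)cc3)c3ccc(Cl)cc3)CC2)C(C)C)c1` has not yet been measured; it differs from compound 3 by isopropyl in place of hydrogen on a nitrogen on an aromatic ring, the same kind of change as from compound 1 to compound 2, at a place described in the same words. He expects a step of about a 5.2-fold higher number from compound 3 to compound 4 (0.72 log units; beyond the scatter), beside the earlier one, because the measured step of a 5.7-fold higher number from compound 1 to compound 2 (0.76 log units; beyond the scatter) is the only guide for this change. Compound 4 is therefore estimated at 2.5 ug/mL, most likely between 0.8 ug/mL and 7 ug/mL.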

Compound 4, half-maximal inhibitory concentration: 2.2 ug/mL
Beside the measured number, compound 4's estimate is 1.1-fold (0.06 log units) above it; measured number inside the range.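

In this assay, isopropyl in place of hydrogen on the aromatic-ring nitrogen again weakens inhibition, giving a 4.6-fold higher number from compound 3 to compound 4 (0.66 log units; beyond the scatter). The change thus carries over between these two cores at much the same size: the same change on two cores in this assay, a 5.7-fold higher number (0.76 log units; beyond the scatter) from compound 1 to compound 2 and a 4.6-fold higher number (0.66 log units; beyond the scatter) from compound 3 to compound 4, 1.3-fold (0.10 log units) apart, within the scatter of two such steps. Among these compounds, this agreement rests on only two pairs, so it does not show that the step would hold on any other core, and it does not explain why the change weakens inhibition.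

The compounds shown leave open how methyl, ethyl or acetyl would behave on that nitrogen in place of isopropyl. They also leave open which of the differences between the two cores accounts for the gap between compound 1 and compound 3.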